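The compounds below may be only part of what the source reports. "The series", "measured", "known", "first", "only" and "open" are said of these compounds alone.

Compound 1 `O=C1Nc2ccc(Br)cc2/C1=N/NC(=S)N/N=C/c1ccc(-c2ccccc2)cc1`: > 50000 nM in a functional assay on COS-7 cells (Chlorocebus aethiops) for inhibition, read by MTT assay (a higher number here means a weaker inhibitor, a lower number a stronger inhibitor), which is a limit of the assay rather than a number.
Compound 2 `O=C1Nc2ccc(Br)cc2/C1=N/NC(=S)N/N=C/c1ccc2ccccc2c1`: > 50000 nM, again a limit and not a number.

Compound 1 therefore stands at the edge of what this assay can report, and both values sit there (the limit of > 50000 nM in this assay, at which 2 of the 2 values shown sit). Among the measured compounds shown here, no pair of measured compounds differing in a single place is available, so no measured step can guide the next change. Compound 3 `O=C1Nc2ccc(Br)cc2/C1=N/NC(=S)N/N=C/c1ccc(Br)cc1` differs from compound 1 by bromo in place of phenyl on an aromatic carbon. No step beyond the usual scatter is expected, so compound 3 is expected to give about 50000 nM, somewhere between 10000 nM and 200000 nM, most likely again only a limit. The expected step is a number no higher from compound 1 to compound 3 (the limit leaves the size open).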

Compound 3, half-maximal inhibitory concentration: 5180 nM
Compound 3: middle estimate off by 9.7-fold (0.98 log units), on the high side, outside the stated range (below it).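

In this assay, this position responds to the group it carries: bromo in place of phenyl gives an at least 9.6-fold lower number from compound 1 to compound 3 (0.98 log units; beyond the scatter). Compound 3 is the first compound shown with a true number, so the shared core is not inactive in itself. The full size of the step stays open, because compound 1 gives only a limit: the limit of > 50000 nM in this assay, at which 2 of the 3 values shown sit.

Whether the gain comes from the bromo itself or simply from losing the phenyl ring remains unclear. A methoxy group, an amine or a carboxylic acid at this place could help separate the two.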